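The source may hold more compounds than are shown below. What is called first, only, known or untested is meant among the compounds shown, and "the series" means these compounds.

Working notes on the series, read in a functional assay on L1210 cells (Mus musculus) for inhibition, read by MTT assay, with a stated time of 72 h; a lower number here means a stronger inhibitor, a higher number a weaker inhibitor. Compound 1 (`COc1cc(NC(C)CCCNC(=O)NNC(=O)Nc2ccc(F)cc2)c2ncccc2c1`) gives 104000 nM. Compound 2 (`COc1cc(NC(C)CCCNC(=O)NNC(=O)Nc2ccc(Cl)cc2)c2ncccc2c1`) gives 58000 nM. Within the data shown here, the only measured neighbour of compound 2 is compound 1, and the two numbers lie within the scatter of each other, so compound 2 holds no separate place in this short series.

Next comes compound 3 (`COc1cc(NC(C)CCCNC(=O)NNC(=O)Nc2ccc(C(F)(F)F)cc2)c2ncccc2c1`), with trifluoromethyl in place of chloro on an aromatic carbon. The rest of the structure stays the same. Among the measured compounds shown here, one measured step bears on this change: a 1.8-fold lower number from compound 1 to compound 2 (0.25 log units; within the scatter), which is also a swap of one group on that aromatic carbon, chloro in place of fluoro. That step stays within the scatter. For the measured compounds named here, it is the only evidence, and no measured compound carries trifluoromethyl. A step beyond the scatter is therefore not expected in this assay, and neither direction is favoured. The expected step is a 1.1-fold lower number from compound 2 to compound 3 (0.02 log units; within the scatter). For compound 3 the estimated value is 55000 nM, with an expected range from 25000 nM to 120000 nM.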

Compound 3, half-maximal inhibitory concentration: 18000 nM
For compound 3 the middle estimate is 3.1-fold (0.49 log units) above the measured one; measured number outside the range, below it.
By their numbers in this assay, from the lowest: compound 3; then compounds 2 and 1 (each within the scatter of the next).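

In this assay, the aromatic carbon para to a large group now shows a step beyond the scatter, which the swap of fluoro for chloro did not: trifluoromethyl in place of chloro gives a 3.2-fold lower number from compound 2 to compound 3 (0.51 log units; beyond the scatter) and so this position does respond to the group it carries. Trifluoromethyl in place of fluoro gives a 5.8-fold lower number from compound 1 to compound 3 (0.76 log units; beyond the scatter) and places compound 3 as the strongest inhibitor of the three, as its steps to both other compounds lie beyond the scatter. Nothing available explains why this swap moves the number when the swap of fluoro for chloro stayed within the scatter.

Among these compounds, with only three groups at this position, it remains open whether the lower number is particular to trifluoromethyl or would also appear with a nitrile, a methoxy group or a carboxylic acid on the same aromatic carbon. Going by these compounds, it is equally open whether the step holds when another part of the shared core changes, for instance with a longer chain in place of the present one.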